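Compound 3 to compound 4: propyl for ethoxy

This account rests on a few compounds, and the source may have more. Where it says the series, first, only, none or still open, it means among the compounds named here.

The series shares one core and varies the group on the amine nitrogen. In a functional assay on MGC-803 cells (Homo sapiens) for inhibition, read by sulforhodamine B assay (on this read-out lower numbers stand for stronger inhibition and higher numbers for weaker inhibition), compound 1 (`O=C1C(Nc2ccccc2F)=CC(=O)c2c1nc1n2[C@H]2OC[C@@H](O)[C@H]2OC1`) gives 2000 nM. Compound 2 (`O=C1C(NC2CCCC2)=CC(=O)c2c1nc1n2[C@H]2OC[C@@H](O)[C@H]2OC1`) is reported only as a limit, > 16000 nM. Compound 3 (`CCOc1ccc(NC2=CC(=O)c3c(nc4n3[C@H]3OC[C@@H](O)[C@H]3OC4)C2=O)cc1`) gives 2090 nM, which places it level with compound 1 within the scatter.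

The next compound, compound 4 (`CCCc1ccc(NC2=CC(=O)c3c(nc4n3[C@H]3OC[C@@H](O)[C@H]3OC4)C2=O)cc1`), keeps the core and the phenyl on the amine nitrogen, but changes the group on that phenyl: propyl in place of ethoxy on an aromatic carbon. Compound 4 thus carries 4-propylphenyl where compound 3 carries 4-ethoxyphenyl.

Going by the values given here, no measured step makes this exchange directly. The closest evidence is the replacement of 2-fluorophenyl by 4-ethoxyphenyl, which gives a 1.0-fold higher number from compound 1 to compound 3 (0.02 log units; within the scatter). The two steps involving cyclopentyl are larger, an at least 8.0-fold higher number from compound 1 to compound 2 (0.90 log units; beyond the scatter) and an at least 7.6-fold lower number from compound 2 to compound 3 (0.88 log units; beyond the scatter), but both rest on the limit of > 16000 nM in this assay, at which 1 of the 3 values shown sits, and both change the whole group on the nitrogen. Compound 4 retains a substituted phenyl there, so the step from compound 1 to compound 3 is the better guide, and no shift beyond the scatter is expected in this assay.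

The expected step is a 1.1-fold higher number from compound 3 to compound 4 (0.02 log units; within the scatter).

For compound 4 the estimated value is 2200 nM, with an expected range of 900 nM to 6000 nM.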

Compound 4, half-maximal inhibitory concentration: 1920 nM
Estimate against measurement, compound 4: 1.1-fold (0.06 log units) above; the measured number falls inside the stated range.
By their numbers in this assay, from the lowest: compounds 4, 1 and 3 (each within the scatter of the next). At a limit, above all of these: compound 2.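

In this assay, the ethoxy group of compound 3 gives way to propyl on the same aromatic carbon, para to a large group, with no shift beyond the scatter: a 1.1-fold lower number from compound 3 to compound 4 (0.04 log units; within the scatter). Going by these compounds alone, the ethoxy oxygen is therefore not required at this level of inhibition, at least between these two compounds, which earlier comparisons of whole nitrogen substituents could not show. The new 4-propylphenyl compound also stays level with the 2-fluorophenyl compound, a 1.0-fold lower number from compound 1 to compound 4 (0.02 log units; within the scatter), while the gap to the cyclopentyl compound recurs with a third substituted phenyl, an at least 8.3-fold lower number from compound 2 to compound 4 (0.92 log units; beyond the scatter), and that step is only a bound since compound 2 is reported as a limit: the limit of > 16000 nM in this assay, at which 1 of the 4 values shown sits.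

Open is whether the para substituent matters at all at this level, since unsubstituted phenyl is not among the compounds shown, and two groups of equal heavy-atom count say little about size. A hexyl chain, a primary amine or a carboxylic acid at the same place would test how far the flat response extends.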